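Swapping the Aryl Group in a Caffeine-Linked Ester Series

The compounds below may be only part of what the source reports. "The series", "measured", "known", "first", "only" and "open" are said of these compounds alone.

Compound 1, `COC(C(=O)OC(C)Cn1cnc2c1c(=O)n(C)c(=O)n2C)c1cccc2ccccc12`: 87.9%
Compound 2, `COC(C(=O)OC(C)Cn1cnc2c1c(=O)n(C)c(=O)n2C)c1ccc2ccccc2c1`: 28.2%

Both compounds were examined in a functional assay on CCRF-CEM cells (Homo sapiens) for antiproliferative activity, read by MTT assay, with a stated time of 72 h, tested at 50 uM; on this read-out higher numbers stand for a weaker effect at the one concentration tested and lower numbers for a stronger effect. Compound 2 stands at the lowest of the two numbers; its nearest neighbour is compound 1, and the step of a number 59.7 percentage points lower from compound 1 to compound 2 (beyond the scatter) was large. Compound 3, `COC(C(=O)OC(C)Cn1cnc2c1c(=O)n(C)c(=O)n2C)c1ccc(C(C)(C)C)cc1`, has not yet been measured. It differs from compound 2 in one place: 4-(tert-butyl)phenyl in place of naphthalen-2-yl on a saturated chain carbon bound to a carbonyl carbon and an oxygen on a saturated carbon. Among the measured compounds shown here, only one measured step bears on this change, and only loosely, since it swapped one naphthalenyl for another rather than replacing the two-ring group with a single ring carrying tert-butyl; it does show that this assay responds strongly to what sits at this position. For the measured compounds named here, with no direct precedent, the estimate for compound 3 is 55%, with a range from 25% to 90%. This corresponds to an expected step of a number 26.8 percentage points higher from compound 2 to compound 3 (beyond the scatter), toward a weaker effect, though with wide uncertainty.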

Compound 3, a percentage reported as activity, at one concentration (the size of the read-out at that concentration, not a potency): 55.3%
Compound 3: middle estimate off by 0.3 percentage points, on the low side; the range from low to high includes it.
By their numbers in this assay, from the lowest: compound 2; then compound 3; then compound 1.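

With 4-(tert-butyl)phenyl at this position, this assay shows a number 27.1 percentage points higher from compound 2 to compound 3 (beyond the scatter) and a number 32.6 percentage points lower from compound 1 to compound 3 (beyond the scatter), so this group falls after naphthalen-2-yl and before naphthalen-1-yl in the order of numbers. Among the compounds shown here, all three groups have the same count of 10 heavy atoms, so that count alone does not fix the read-out, and the single aromatic ring of compound 3 gives a lower number than the two rings of compound 1 but a higher one than the two rings of compound 2. Nothing measured here accounts for this order.

The compounds shown leave open how much of these steps belongs to the tert-butyl group and how much to the single ring, a question a plain phenyl group at this place would address. They also leave open how a ring bearing an amine or a carboxylic acid would read.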